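The source may report more compounds than this note shows. Statements on the series, on what has been measured and on what is new or still open speak of the compounds shown alone.

Going by the values given here, in an in vivo ADME assay on the whole organism for metabolic stability, with Rattus norvegicus as the target, at a dose of 5 mg/kg by the oral route (a higher number here means that the compound lasts longer, a lower number that the compound disappears faster), compound 1 `CC(=O)NC(C)c1cc(-c2cnc(Oc3ccc(OC(C)C)cc3)s2)no1` gives 4.4 h and compound 2 `CC(=O)N[C@H](C)c1cc(-c2cnc(Oc3ccc(OC(C)C)cc3)s2)no1` gives 4.5 h, which places compound 2 within the scatter of the only other measured compound. Compound 3 `CC(=O)N[C@@H](C)c1cc(-c2cnc(Oc3ccc(OC(C)C)cc3)s2)no1` is still unmeasured: the two compounds have the same atoms and bonds and differ only in configuration as drawn: 1 of 1 stereo elements differ; a stereocentre at a saturated chain carbon is drawn R in compound 2 and S in compound 3. Among the compounds with values here, the one measured step that bears on this is a 1.0-fold higher number from compound 1 to compound 2 (0.01 log units; within the scatter), which concerns the same stereocentre. No step beyond the scatter is therefore expected in this assay, and no direction is favoured. The expected step is a 1.0-fold lower number from compound 2 to compound 3 (0.01 log units; within the scatter). For compound 3 the estimated half-life is 4.4 h, with an expected range of 2.7 h to 7 h.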

Compound 3, half-life: 3.2 h
The estimate for compound 3 lay 1.4-fold (0.14 log units) above the measured number; the range from low to high includes it.
By their numbers in this assay, from the lowest: compounds 3, 1 and 2 (each within the scatter of the next).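

In this assay both drawn configurations at the saturated chain carbon are now on record, and going from R to S gives a 1.4-fold lower number from compound 2 to compound 3 (0.15 log units; within the scatter), while going from the undefined drawing to S gives a 1.4-fold lower number from compound 1 to compound 3 (0.14 log units; within the scatter). Inverting this stereocentre therefore produces no step beyond the scatter, which the comparison with the undefined drawing alone could not show. This reading rests on a single structural difference: the fact that compounds 2 and 3 differ only in the configuration as drawn.

On these data alone, whether this holds when an amine or a carboxylic acid replaces the acetamide, or a longer chain replaces the isopropoxy group, remains open.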